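This account rests on a few compounds, and the source may have more. Where it says the series, first, only, none or still open, it means among the compounds named here.

Measured so far in a functional assay for inhibition; a lower number here means a stronger inhibitor, a higher number a weaker inhibitor:
- compound 1 `CC(C)(C)c1cc(-c2cc(=O)c3ccc(OCc4ccc5ccccc5n4)cc3o2)cc(C(C)(C)C)c1O`: 3000 nM
- compound 2 `CN(C)CCCOc1ccc2c(=O)cc(-c3cc(C(C)(C)C)c(O)c(C(C)(C)C)c3)oc2c1`: 700 nM

Compound 2 stands at 700 nM as the lower of the two numbers, which makes it the stronger inhibitor of this pair. Compound 3 `CC(C)(C)c1cc(-c2cc(=O)c3ccc(OCC(=O)N4CCCCC4)cc3o2)cc(C(C)(C)C)c1O` keeps the shared core and changes one group: (piperidin-1-yl)carbonyl comes in place of 2-(dimethylamino)ethyl on a saturated chain carbon bound to an oxygen on an aromatic ring (piperidin-1-yl)carbonyl in place of 2-(dimethylamino)ethyl on a saturated chain carbon bound to an oxygen on an aromatic ring in that exchange.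

Going by the values given here, only one measured step bears on this place. It is a 4.3-fold lower number from compound 1 to compound 2 (0.63 log units; beyond the scatter) and came with 2-(dimethylamino)ethyl replacing quinolin-2-yl. So the group here can shift the number modestly, though a single step is thin evidence. Among the compounds with values here, compound 1 at 3000 nM is the only measured compound without 2-(dimethylamino)ethyl, so removing that group is expected to move the number back towards that value. The expected change is a 2.1-fold higher number from compound 2 to compound 3 (0.33 log units; beyond the scatter) in this assay and points to a weaker inhibitor. For compound 3 the estimated value is 1500 nM with an expected range from 500 nM to 5000 nM for a measurement.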

Compound 3, half-maximal inhibitory concentration: 3000 nM
Compound 3: the middle estimate sits 2.0-fold (0.30 log units) below what was measured; the range from low to high includes it.
By their numbers in this assay, from the lowest: compound 2; then compounds 1 and 3 (each within the scatter of the next).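

Exchanging 2-(dimethylamino)ethyl for (piperidin-1-yl)carbonyl gives a 4.3-fold higher number from compound 2 to compound 3 (0.63 log units; beyond the scatter) in this assay, so the earlier gain at this place does not follow simply from removing quinolin-2-yl. Exchanging quinolin-2-yl for (piperidin-1-yl)carbonyl gives no change at the digits printed from compound 1 to compound 3 (within the scatter) in this assay, which means that two very different groups, one containing a six-membered non-aromatic ring and a carbonyl, share the same number here. Among these three compounds, compound 2 is the strongest inhibitor and the only one with a 3-(dimethylamino)propyl chain on the oxygen, but nothing available explains this difference.

The step from 2-(dimethylamino)ethyl to (piperidin-1-yl)carbonyl changes the chain, the ring and the carbonyl together, so it cannot show which of these features accounts for the change in number. A shorter or longer chain ending in the same dimethylamino group, a chain ending in a piperidine without the carbonyl, or one ending in a morpholine or a carboxylic acid could help separate these features.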